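A Methylphenyl Swap on a Near-Inactive Scaffold

The compounds below may be only part of what the source reports. "The series", "measured", "known", "first", "only" and "open" are said of these compounds alone.

Compound 1 `CS(=O)(=O)c1ccc(-c2cnc3[nH]cc(-c4nnc(-c5ccncc5)o4)c(=O)c3c2)cc1` gives the highest of three numbers in a functional assay on MCF7 cells (Homo sapiens) for inhibition, read by MTT assay, with a stated time of 24 h, tested at 5 uM (on this read-out lower numbers stand for less inhibition of growth and higher numbers for more inhibition of growth at the one concentration tested), namely 2.35%, yet the margin is slight. Compound 2 `CS(=O)(=O)c1ccc(-c2cnc3[nH]cc(-c4nnc(-c5ccccc5)o4)c(=O)c3c2)cc1` gives 1.38% and compound 3 `CS(=O)(=O)c1ccc(-c2cnc3[nH]cc(-c4nnc(-c5ccc(Cl)cc5)o4)c(=O)c3c2)cc1` gives 0.86%; the steps of a number 1 percentage points lower from compound 1 to compound 2 (within the scatter) and a number 1.5 percentage points lower from compound 1 to compound 3 (within the scatter) both fall within the scatter, so the three cannot be told apart. Compound 4 `Cc1ccc(-c2nnc(-c3c[nH]c4ncc(-c5ccc(S(C)(=O)=O)cc5)cc4c3=O)o2)cc1` differs from compound 1 by 4-methylphenyl in place of pyridin-4-yl on an aromatic carbon. The two measured steps that replace the pyridin-4-yl group with a carbon-only ring bear directly on this change, and neither moved the number beyond the scatter. The step of a number 0.9 percentage points lower from compound 1 to compound 4 (within the scatter) is therefore expected to stay within the scatter as well. For compound 4 the estimate in this assay is 1.5%, with a range from -6% to 9%.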

Compound 4, percent growth inhibition at one concentration: 6.26%
Estimate against measurement, compound 4: 4.8 percentage points below, and the stated range covers the measured number.
By their numbers in this assay, from the lowest: compounds 3, 2, 1 and 4 (each within the scatter of the next).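

At this position, 4-methylphenyl in place of pyridin-4-yl gives a number 3.9 percentage points higher from compound 1 to compound 4 (within the scatter) in this assay and so joins the two carbon-only rings already seen. On that same ring, methyl in place of hydrogen gives a number 4.9 percentage points higher from compound 2 to compound 4 (within the scatter) and methyl in place of chloro gives a number 5.4 percentage points higher from compound 3 to compound 4 (within the scatter) here, so none of these swaps separates the four compounds.

As far as these compounds go, whether an amine or a carboxylic acid on this ring would lift the number clear of the scatter stays open. No measurement at hand bears on why these rings read alike.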